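Chloro for cyano on the pendant phenyl of a bicyclic core

The source may hold more compounds than are shown below. What is called first, only, known or untested is meant among the compounds shown, and "the series" means these compounds.

Compound 1 `c1ccc(C2Cc3nccn3C2)cc1` — > 10000 nM; 7360 nM; > 10000 nM; > 10000 nM (4 entries)
Compound 2 `NC(=O)c1ccccc1C1Cc2nccn2C1` — "not determined" (no result reported)
Compound 3 `N#Cc1ccccc1C1Cc2nccn2C1` — > 10000 nM

All three measured compounds share one core and differ in the substituent on the phenyl ring. In a functional assay on CHO cells for agonist activity at Alpha-1D adrenergic receptor (Homo sapiens), read by FLIPR and calcium flux (on this read-out higher numbers stand for an effect only at larger amounts of compound and lower numbers for an effect already at smaller amounts), compound 1 gives > 10000 nM; 7360 nM; > 10000 nM; > 10000 nM (4 entries), several entries that leave it without one single number (the several entries of compound 1 in this assay, > 10000 nM; 7360 nM; > 10000 nM; > 10000 nM (4 entries)). For compound 2 in this assay no result is reported "not determined" (no result reported). Compound 3, the nitrile, gives in this assay > 10000 nM, which is a limit of the assay and not a number (the limit of > 10000 nM in this assay, at which 1 of the 3 values shown sits). Compound 3 therefore stands at the top of the measured range, with no single number to place it more precisely.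

Compound 4 `Clc1ccccc1C1Cc2nccn2C1` is not yet measured. It differs from compound 3 by chloro in place of cyano on an aromatic carbon. Within the data shown here, no step between measured compounds is available to guide this change, and the only reference points, compound 1 and compound 3, both sit essentially at the limit. The expectation is therefore for no step beyond the scatter: compound 4 is expected to remain weak in this assay, with an at least 1.1-fold lower number from compound 3 to compound 4 (0.04 log units; that floor lies within the scatter) meaning little change, and an estimated 9000 nM within a range from 2500 nM to 30000 nM, with a substantial chance that again only a limit is reported.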

Compound 4, half-maximal effective concentration: 364 nM
Compound 4: middle estimate off by 25-fold (1.39 log units), on the high side; the whole stated range lies above it.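

In this assay, replacing cyano with chloro on an aromatic carbon of the phenyl ring, ortho to a group of 8 heavy atoms, gives an at least 27-fold lower number from compound 3 to compound 4 (1.43 log units; beyond the scatter), so a single exchange at this position separates a compound at the limit of the assay from one with a measured number. Going by these compounds, the true size of the step remains unknown, and only its floor can be stated, because compound 3 stands at a limit rather than at a number: the limit of > 10000 nM in this assay, at which 1 of the 4 values shown sits. Compound 1, which carries neither cyano nor chloro, also fails to give a single number, so the shared core alone does not account for the value of compound 4: the several entries of compound 1 in this assay, > 10000 nM; 7360 nM; > 10000 nM; > 10000 nM (4 entries).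

Whether a methyl, a methoxy or a bromo group at this position would behave like chloro remains open, so the compounds shown establish no trend across substituents. With chloro represented by compound 4 alone, they also cannot show which feature of that group matters at this position.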